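From a nitrobenzamide to an isobutyl carbamate

A few compounds are considered here, and "the series" means these few. Any claim that something is new, unique, unknown or untested is made for them only; others in the source may bear on it.

Going by the values given here, compound 1 `CCc1cc(S(=O)(=O)N2C[C@H](c3ccccc3)NC2=O)ccc1NC(=O)c1ccc([N+](=O)[O-])cc1` is the anchor of this small set: in a functional assay on HCT-116 cells (Homo sapiens) for cytotoxicity, read by MTT assay (on this read-out higher numbers stand for weaker inhibition and lower numbers for stronger inhibition), compound 1 gives 500 nM, the only actual number among the three measured values. Compound 2 `CC1[C@H](c2ccccc2)NC(=O)N1S(=O)(=O)c1ccc(NC(=O)c2ccc([N+](=O)[O-])cc2)c(Cl)c1` gives > 10000 nM in this assay, which is a limit of the assay and not a number. Compound 3 `CC1[C@H](c2ccccc2)NC(=O)N1S(=O)(=O)c1ccc(NC(=O)c2ccc(N)cc2)c(Cl)c1` likewise gives > 10000 nM in this assay, again a limit. Both of these values sit at the limit of > 10000 nM in this assay, at which 2 of the 3 values shown sit, so the step that the two limits leave unreadable from compound 2 to compound 3 stays unreadable.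

Compound 4 `CCc1cc(S(=O)(=O)N2C[C@H](c3ccccc3)NC2=O)ccc1NC(=O)OCC(C)C` differs from compound 1 by isobutoxy in place of 4-nitrophenyl on a carbonyl carbon. Among the compounds with values here, none of the measured steps touches this part of the molecule; the one recorded step concerns the nitro group and is itself unreadable, so nothing measured here bears on the change. The expectation for compound 4 must therefore rest on compound 1 alone, with wide uncertainty in either direction, and some chance that compound 4 also reaches only a limit. Compound 4 is expected to give 2000 nM, with an estimated range from 400 nM to 10000 nM. This corresponds to an expected step of a 4.0-fold higher number from compound 1 to compound 4 (0.60 log units; beyond the scatter).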

Compound 4, half-maximal inhibitory concentration: 60 nM
Compound 4: middle estimate off by 33-fold (1.52 log units), on the high side, and the stated range ends above it.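

Putting isobutoxy in place of 4-nitrophenyl on the carbonyl carbon gives an 8.3-fold lower number from compound 1 to compound 4 (0.92 log units; beyond the scatter) in this assay, so in this pair the six-membered aromatic ring and the nitro group can both leave without any loss of activity. Going by these compounds alone, this is the only step in the set that can be read, since the one between compound 2 and compound 3 joins two limits of the assay. Nothing shown gives a cause for this step.

The compounds shown leave open whether the gain comes from losing the nitro group or the ring, which a plain phenyl on the same carbonyl carbon would help to separate, and how a shorter or longer chain in place of isobutoxy would read. Also open, on these data alone, is whether the same exchange would carry over to compound 2, which differs from compound 1 elsewhere in the molecule.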